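The source may hold more compounds than are shown below. What is called first, only, known or untested is meant among the compounds shown, and "the series" means these compounds.

Working notes on the series. The shared core carries an amide, and compound 2 `Cc1cnc(Nc2ccc(C(=O)Nc3c(C)cccc3C)cc2)nc1-c1ccc(OC(F)(F)F)cc1` is the reference. Within the data shown here, in an assay on NIH3T3 cells for inhibition of Sonic hedgehog protein (Mus musculus), read by a luciferase reporter, with a stated time of 48 h (a lower number here means a stronger inhibitor, a higher number a weaker inhibitor), compound 2 gives 1.3 nM, the lowest of the three numbers measured so far. Compound 3 `Cc1cnc(Nc2ccc(C(=O)Nc3c(C)cccc3C)cc2)nc1-c1ccc(C#N)cc1` gives 2.8 nM in this assay, and compound 1 `Cc1ccccc1C(=O)Nc1ccc(Nc2ncc(C)c(-c3ccc(OC(F)(F)F)cc3)n2)cc1` gives 42.1 nM. Compound 4 `Cc1cnc(Nc2ccc(C(=O)NC(C)C)cc2)nc1-c1ccc(OC(F)(F)F)cc1` is not yet measured; relative to compound 2 it carries isopropyl in place of 2,6-dimethylphenyl on an amide-type nitrogen. Among the measured compounds shown here, only the step of a 32-fold lower number from compound 1 to compound 2 (1.51 log units; beyond the scatter) touches the amide end of the molecule, and it was large; the step of a 2.2-fold higher number from compound 2 to compound 3 (0.33 log units; beyond the scatter) sits at the other end and was modest. The amide substituent therefore looks sensitive, and replacing the aromatic ring there by a three-carbon chain is expected to weaken inhibition: compound 4 is estimated at 20 nM (range 4 nM to 100 nM), a step of a 15-fold higher number from compound 2 to compound 4 (1.19 log units; beyond the scatter).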

Compound 4, half-maximal inhibitory concentration: 73.1 nM
Estimate against measurement, compound 4: 3.7-fold (0.56 log units) below, and the stated range covers the measured number.
By their numbers in this assay, from the lowest: compound 2; then compound 3; then compounds 1 and 4 (each within the scatter of the next).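

On an amide-type nitrogen, isopropyl in place of 2,6-dimethylphenyl gives a 56-fold higher number from compound 2 to compound 4 (1.75 log units; beyond the scatter) in this assay, so the low number of compound 2 depends on the group at this nitrogen and not on the amide alone. With a 1.7-fold higher number from compound 1 to compound 4 (0.24 log units; within the scatter) in this assay, isopropylcarbamoyl and ((2-methylphenyl)carbonyl)amino are not separated on this aromatic carbon. No measurement on hand gives a reason for either step. As far as these compounds go, whether the ring or its two methyl groups matter stays open: a plain phenyl and a cyclohexyl on the same nitrogen would help to separate them.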